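From phenyl to pentyl on a shared core

The source may hold more compounds than are shown below. What is called first, only, known or untested is meant among the compounds shown, and "the series" means these compounds.

Measured so far in a physicochemical assay for solubility (on this read-out lower numbers stand for lower solubility and higher numbers for higher solubility), and each value a limit of the assay:
compound 1 (`Nc1cccc2c(=O)[nH]c(-c3ccccc3)cc12`) gives > 30000000 nM as a limit
compound 2 (`COc1ccc(-c2cc3c(N)cccc3c(=O)[nH]2)cc1`) gives > 30000000 nM as a limit
compound 3 (`Nc1cccc2c(=O)[nH]c(-c3ccc(Cl)cc3)cc12`) gives > 30000000 nM as a limit

Compound 1 has no numerical value to stand on, only its limit of > 30000000 nM in this account. The series as a whole offers the limit of > 30000000 nM in this assay, at which 3 of the 3 values shown sit, and nothing finer to compare.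

Compound 4 (`CCCCCc1cc2c(N)cccc2c(=O)[nH]1`) keeps the core of compound 1 and carries pentyl in place of phenyl on an aromatic carbon next to the ring nitrogen. The measured steps in this assay give little to go on. The record shows a step that the two limits leave unreadable from compound 1 to compound 2 and also a step that the two limits leave unreadable from compound 1 to compound 3 and finally a step that the two limits leave unreadable from compound 2 to compound 3 in the same series. None of these has a readable size, and none replaces the phenyl group itself, so no size or direction can be carried over to this change.

The expected outcome is a number no higher from compound 1 to compound 4 (the limit leaves the size open) as an estimate only. For compound 4 the estimated value is 30000000 nM with an expected range from 10000000 nM to 60000000 nM and the assay may well report only a limit again.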

Compound 4, solubility: > 30000000 nM
Compound 4: a limit, no number; the forecaster's own chance of this, stated with the estimate: 80%; the middle value sits exactly at the limit.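

In this assay compound 4 gives > 30000000 nM, a limit and not a number. The step between compound 1 and compound 4 therefore cannot be read, and the series stays where it was: the limit of > 30000000 nM in this assay, at which 4 of the 4 values shown sit. The compounds shown leave open what the solubility of any of them is, and whether pentyl in place of phenyl changes it.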